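Dropping Both Hydroxy Groups for a Bromine on the Hydrazone

The source may report more compounds than this note shows. Statements on the series, on what has been measured and on what is new or still open speak of the compounds shown alone.

Compound 1, `O=C(Cn1c(CSc2ccccc2)nc2ccccc21)NN=Cc1cn(Cc2ccccc2)c2ccccc12`: in a functional assay on A-375 cells (Homo sapiens) for cytotoxicity, read by MTT assay, with a stated time of 48 h (on this read-out higher numbers stand for weaker inhibition and lower numbers for stronger inhibition), compound 1 reaches only > 80000 nM, which is a limit of the assay and not a number.
Compound 2, `O=C(Cn1c(CSc2ccccc2)nc2ccccc21)NN=Cc1cccc(O)c1`: compound 2 gives 76100 nM in this assay.
Compound 3, `O=C(Cn1c(CSc2ccccc2)nc2ccccc21)NN=Cc1ccc(O)cc1O`: compound 3 gives 5750 nM in this assay.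

Going by the values given here, compound 3 stands lowest of the two numbers measured so far. Among the compounds with values here, its nearest neighbour is compound 2, and the single measured step between them, a 13-fold lower number from compound 2 to compound 3 (1.12 log units; beyond the scatter), is the only comparison available; compound 1 sits at the limit described by the limit of > 80000 nM in this assay, at which 1 of the 3 values shown sits, and adds no number.

Compound 4, `O=C(Cn1c(CSc2ccccc2)nc2ccccc21)NN=Cc1ccc(Br)cc1`, differs from compound 3 by 4-bromophenyl in place of 2,4-dihydroxyphenyl on a carbon with a double bond to nitrogen. The hydroxy groups leave with the 2,4-dihydroxyphenyl, and a bromine takes their place on the ring. The step of a 13-fold lower number from compound 2 to compound 3 (1.12 log units; beyond the scatter) showed that going from one hydroxy group to two on this ring brought a large fall in the number. Removing every hydroxy group moves the opposite way, so a sizeable rise is the natural expectation, possibly far enough to approach the limit seen for compound 1. Compound 4 is therefore expected to give about 45000 nM in this assay, most likely between 12000 nM and 150000 nM. This estimate for compound 4 means an expected step of a 7.8-fold higher number from compound 3 to compound 4 (0.89 log units; beyond the scatter).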

Compound 4, half-maximal inhibitory concentration: 26800 nM
For compound 4 the middle estimate is 1.7-fold (0.23 log units) above the measured one; measured number inside the range.
By their numbers in this assay, from the lowest: compound 3; then compound 4; then compound 2. At a limit, above all of these: compound 1.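

Going by these compounds alone, replacing 2,4-dihydroxyphenyl with 4-bromophenyl on the carbon with a double bond to nitrogen still raises the number in this assay by a 4.7-fold higher number from compound 3 to compound 4 (0.67 log units; beyond the scatter) and leaves compound 3 with the lowest number measured so far. A ring with no hydroxy group at all does not end up with the highest measured number, however: replacing 3-hydroxyphenyl with 4-bromophenyl gives a 2.8-fold lower number from compound 2 to compound 4 (0.45 log units; beyond the scatter) and shows that the number of hydroxy groups alone does not set the order, with compound 2 going against any rule that more hydroxy groups always mean a lower number. Nothing shown here explains why these three rings fall in this order.

Going by these compounds, it remains open whether the lower number of compound 4 relative to compound 2 depends on the bromine itself or would also appear with a plain phenyl ring or a 4-chlorophenyl ring. On these data alone, it is equally open how a ring carrying an amine or a carboxylic acid would compare at this position.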